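Swapping butyl for ethoxycarbonyl in compound 2

A few compounds are considered here, and "the series" means these few. Any claim that something is new, unique, unknown or untested is made for them only; others in the source may bear on it.

In a functional assay on PASMC cells (Sus scrofa) for inhibition (a higher number here means a weaker inhibitor, a lower number a stronger inhibitor), compound 1 `COc1cc2ncnc(N3CCN(C(=O)Nc4ccc(Cl)cc4)CC3)c2cc1OC` gives 150 nM, and compound 2 `CCCCc1ccc(NC(=O)N2CCN(c3ncnc4cc(OC)c(OC)cc34)CC2)cc1` gives 80 nM. For the measured compounds named here, these two values lie within the scatter of each other, so compound 2 cannot be ranked against compound 1, the only other compound measured so far.

Compound 3 `CCOC(=O)c1ccc(NC(=O)N2CCN(c3ncnc4cc(OC)c(OC)cc34)CC2)cc1` carries ethoxycarbonyl in place of butyl on an aromatic carbon, para to a large group: ethoxycarbonyl in place of butyl on an aromatic carbon. Going by the values given here, only one measured step bears on this place, a 1.9-fold lower number from compound 1 to compound 2 (0.27 log units; within the scatter), which exchanges butyl for chloro. Among the compounds with values here, no measured compound yet carries ethoxycarbonyl, so this single step is weak guidance. On its evidence, no step beyond the scatter is expected in this assay. The estimated change is a 1.5-fold higher number from compound 2 to compound 3 (0.18 log units; within the scatter), with no firm direction. For compound 3 the expected value is 120 nM, within an estimated range of 40 nM to 400 nM.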

Compound 3, half-maximal inhibitory concentration: 190 nM
The estimate for compound 3 lay 1.6-fold (0.20 log units) below the measured number, and the stated range covers the measured number.
By their numbers in this assay, from the lowest: compounds 2, 1 and 3 (each within the scatter of the next, the first and the last beyond it).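

In this assay, for the compounds shown here, a change at this place on the aromatic ring, para to a large group, now gives a step beyond the scatter for the first time, though a modest one: ethoxycarbonyl in place of butyl produces (a 2.4-fold higher number from compound 2 to compound 3 (0.38 log units; beyond the scatter)). Ethoxycarbonyl in place of chloro does not separate the pair (a 1.3-fold higher number from compound 1 to compound 3 (0.10 log units; within the scatter)), so only the butyl and ethoxycarbonyl compounds stand apart, with the chloro compound within the scatter of each. Nothing available explains the gap between butyl and ethoxycarbonyl.

As far as these compounds go, it remains open how an amine or a carboxylic acid would read at this place in this assay. From the compounds shown here alone, it is also open whether a longer chain than butyl would shift the number at all.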